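The source may hold more compounds than are shown below. What is called first, only, known or untested is meant among the compounds shown, and "the series" means these compounds.

In a functional assay on A549 cells (Homo sapiens) for antiproliferative activity, read by MTT assay, with a stated time of 48 h (a lower number here means a stronger inhibitor, a higher number a weaker inhibitor), compound 1 `CC(=O)OC/C1=C/C[C@](C)(CCC=C(C)C)/C=C/[C@@H](OC(=O)C=C(C)C)[C@](C)(O)/C=C/C1=O` gives 2950 nM. Compound 2 `CC(C)=CCC[C@]1(C)/C=C/[C@@H](OC(=O)C=C(C)C)[C@](C)(O)/C=C/C(=O)/C(C(=O)O)=C\C1` is reported only as > 10000 nM, which is a limit of the assay and not a number. Carboxy in place of acetoxymethyl on a double-bonded ring carbon made up the only measured step, an at least 3.3-fold higher number from compound 1 to compound 2 (0.53 log units; beyond the scatter). Compound 3 `CC(C)=CCC[C@]1(C)/C=C/[C@@H](OC(=O)C=C(C)C)[C@](C)(O)/C=C/C(=O)/C(CN(C(C)C)C(C)C)=C\C1` is altered at that same carbon: (diisopropylamino)methyl in place of carboxy on a double-bonded ring carbon, with (diisopropylamino)methyl in place of carboxy. Compound 1 also lacks carboxy and gives 2950 nM, so a return toward that value is expected. The expected step is an at least 2.5-fold lower number from compound 2 to compound 3 (0.39 log units; beyond the scatter), toward a lower number. Compound 3 is estimated at 4000 nM, within an expected range of 1300 nM to 12000 nM.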

Compound 3, half-maximal inhibitory concentration: 650 nM
Estimate against measurement, compound 3: 6.2-fold (0.79 log units) above; the whole stated range lies above it.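

In this assay, this double-bonded ring carbon proves to accept an amine: (diisopropylamino)methyl in place of carboxy gives an at least 15-fold lower number from compound 2 to compound 3 (1.18 log units; beyond the scatter), and the same group in place of acetoxymethyl gives a 4.5-fold lower number from compound 1 to compound 3 (0.66 log units; beyond the scatter), so it goes past the earlier ester as well as recovering the loss seen with carboxy. Compound 2 stands at a limit of the assay, so the first of these steps is a bound and not a measured size: the limit of > 10000 nM in this assay, at which 1 of the 3 values shown sits.

On these data alone, what a smaller (dimethylamino)methyl group or a ring amine such as piperidinylmethyl would give at this carbon stays open. So does whether the nitrogen or its isopropyl groups carry the gain.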